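An Ester Exchange on the Shared Core

This account rests on a few compounds, and the source may have more. Where it says the series, first, only, none or still open, it means among the compounds named here.

Compound 1 `CC1=CC[C@H]2[C@H](CC[C@]2(C)O)C(C)(C)[C@@H]1CC[C@H]1[C@]2(C)CC[C@H](OC(=O)CCC(=O)O)C(C)(C)O[C@H]2CC[C@@]1(C)O` — > 50000 nM
Compound 2 `CC1=CC[C@H]2[C@@H]1CC=C(C)[C@@H](CC[C@H]1[C@]3(C)CC[C@H](OC(=O)c4ccncc4)C(C)(C)O[C@H]3CC[C@@]1(C)O)C2(C)C` — > 50000 nM

Of the compounds shown here, two have been measured in a functional assay on MCF7 cells (Homo sapiens) for antiproliferative activity, read by MTT assay, with a stated time of 72 h; a lower number here means a stronger inhibitor, a higher number a weaker inhibitor. Compound 1 gives > 50000 nM, which is a limit of this assay rather than a number. Compound 2 gives > 50000 nM, again a limit and not a number. Both values sit at the limit of > 50000 nM in this assay, at which 2 of the 2 values shown sit, so neither compound reaches a measurable point, and compound 1 cannot be placed relative to compound 2 beyond that.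

Compound 3 `CC1=CC[C@H]2[C@H](CC[C@]2(C)O)C(C)(C)[C@@H]1CC[C@H]1[C@]2(C)CC[C@H](OC(=O)c3ccccc3Cl)C(C)(C)O[C@H]2CC[C@@]1(C)O` is the next compound to be measured. It differs from compound 1 in one place: 2-chlorophenyl in place of 2-carboxyethyl on a carbonyl carbon. The ester oxygen and the carbonyl stay where they are; what changes is the group on the carbonyl carbon.

Among the compounds with values here, no step between measured compounds is available to guide the size of this change. With both measured compounds at the limit, the step from compound 1 to compound 3 is expected to be an at least 1.6-fold lower number from compound 1 to compound 3 (0.22 log units; that floor lies within the scatter), in the direction of a stronger inhibitor but without confidence that it passes the scatter. Compound 3 is therefore estimated at 30000 nM, within a range from 8000 nM to 60000 nM.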

Compound 3, half-maximal inhibitory concentration: 12100 nM
Compound 3: the middle estimate sits 2.5-fold (0.39 log units) above what was measured, and the stated range covers the measured number.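

In this assay, compound 3 is the first compound shown to give a number rather than a limit, which shows that the shared core can register in this read-out when the ester is suitably changed. Placing 2-chlorophenyl instead of 2-carboxyethyl on the carbonyl carbon gives an at least 4.1-fold lower number from compound 1 to compound 3 (0.61 log units; beyond the scatter), so the group at this place has a bearing on antiproliferative activity in MCF7 cells. The value of compound 1 is a limit, so this step is only a floor and its full size remains unknown: the limit of > 50000 nM in this assay, at which 2 of the 3 values shown sit.

The single step changes several things at once, as the chlorine and the aromatic ring enter while the carboxylic acid and its two-carbon link leave, and the compounds shown cannot separate these contributions. On these data alone, it also remains open how an unsubstituted phenyl, a fluorophenyl or a chain bearing an amine would compare on the same carbonyl carbon of the core of compound 1.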